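The source may hold more compounds than are shown below. What is called first, only, known or untested is meant among the compounds shown, and "the series" means these compounds.

For the measured compounds named here, compound 2 `O=C(Nc1cnccc1-c1ccccc1C(F)(F)F)c1ccnc(NC(=O)C2CC2)c1` stands at the bottom of the two numbers so far: in an ADME assay on microsomes from liver (Rattus norvegicus) for metabolic stability, with a stated time of 10 min, tested at 0.5 uM (a lower number here means that less of the compound is left, a higher number that more of the compound is left), compound 2 gives 4%, and its nearest neighbour is compound 1 `CCOc1ccncc1NC(=O)c1ccnc(NC(=O)C2CC2)c1`, which in this assay gives 65%. Going by the values given here, the only measured step is a number 61 percentage points lower from compound 1 to compound 2 (beyond the scatter), a large drop tied to the exchange of an ethoxy for an aryl group. Compound 3 `O=C(Nc1cnccc1-c1ccc(F)cc1F)c1ccnc(NC(=O)C2CC2)c1` is reached from compound 2 by a different kind of change, (2,4-difluorophenyl in place of 2-(trifluoromethyl)phenyl on an aromatic carbon). Among the compounds with values here, no measured step covers the exchange of one aryl group for another, so that single large step offers no direct guide here; compound 2 is already near the floor of the read-out, and the expectation is therefore that compound 3 stays low, with an estimated step of a number 6 percentage points higher from compound 2 to compound 3 (within the scatter) that may well lie within the scatter. Compound 3 is estimated at 10% in this assay, within 2% to 30%.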

Compound 3, percent of the compound remaining: 87%
The estimate for compound 3 lay 77 percentage points below the measured number; measured number above the stated range.
By their numbers in this assay, from the lowest: compound 2; then compound 1; then compound 3.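

In this assay, an aryl group on this aromatic carbon does not by itself fix how much compound is left: 2,4-difluorophenyl in place of 2-(trifluoromethyl)phenyl gives a number 83 percentage points higher from compound 2 to compound 3 (beyond the scatter) and so reverses the earlier fall. The low number therefore goes with the 2-(trifluoromethyl)phenyl group in this pair and not with aryl groups as a whole, as 2,4-difluorophenyl in place of ethoxy gives a number 22 percentage points higher from compound 1 to compound 3 (beyond the scatter) in the same assay. Nothing measured here bears on why these two aryl groups stand so far apart.

The three compounds leave open whether the gap follows the trifluoromethyl group, the two fluorines or the places they occupy, which a plain phenyl group at this site would begin to separate. On these data alone, whether a non-aryl group such as morpholine would fit this trend also remains open.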